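This account rests on a few compounds, and the source may have more. Where it says the series, first, only, none or still open, it means among the compounds named here.

Compound 1 `CCC(C)NC(=C\C(=O)/C=C/c1ccc(O)c(OC)c1)/C=C/c1ccc(O)c(OC)c1`: 66%
Compound 2 `COc1cc(/C=C/C(=O)/C=C(/C=C/c2ccc(OC(C)=O)c(OC)c2)NCC(C)C)ccc1OC(C)=O`: 77%
Compound 3 `COc1cc(/C=C/C(=O)/C=C(/C=C/c2ccc(O)c(OC)c2)NCC(C)C)ccc1O`: 74%

All three were tested in a functional assay on Caco-2 cells (Homo sapiens), read by fluorescence, tested at 10 uM; a higher number here means a weaker effect of the compound at the concentration tested, a lower number a stronger effect. Compound 3 and compound 1 differ in one place: sec-butyl in place of isobutyl on an amine nitrogen This change gave a number 8 percentage points lower from compound 3 to compound 1 (within the scatter). Compound 2 carries a different core from compound 3; the difference between the two cores is not broken down here, and in this assay compound 2 gives 77% beside the value of compound 3.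

Compound 4 `CCC(C)NC(=C\C(=O)/C=C/c1ccc(OC(C)=O)c(OC)c1)/C=C/c1ccc(OC(C)=O)c(OC)c1` is not yet measured. Among the measured compounds shown here, it stands to compound 2 as compound 1 stands to compound 3, with the same change at the same place: sec-butyl in place of isobutyl on an amine nitrogen Since the earlier step stayed within the usual scatter, the step from compound 2 to compound 4 in this assay is expected to be small as well, about a number 6 percentage points lower from compound 2 to compound 4 (within the scatter), resting on a number 8 percentage points lower from compound 3 to compound 1 (within the scatter) as the only measured example of this change. On that basis compound 4 is estimated to give 71% in this assay, likely between 58% and 84%.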

Compound 4, a percentage reported as activity, at one concentration (the size of the read-out at that concentration, not a potency): 86%
Beside the measured number, compound 4's estimate is 15 percentage points below it, outside the stated range (above it).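

Carried to the core of compound 2, the change of isobutyl to sec-butyl on the amine nitrogen gave a number 9 percentage points higher from compound 2 to compound 4 (within the scatter) in this assay, and set beside the earlier step it does not behave the same way: the same change on two cores in this assay, a number 8 percentage points lower (within the scatter) from compound 3 to compound 1 and a number 9 percentage points higher (within the scatter) from compound 2 to compound 4, 17 percentage points apart, beyond the scatter of two such steps. So what this change does in this pair of cores depends on the core it sits on, and a step measured on one of these cores is a poor guide to the step on the other. It does not show why the two cores part ways, and since each step alone stays within the scatter and there are only two of them, it gives no rule for any further core.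

The compounds shown leave open how the change would read on a third core. They also leave open what a longer chain or a ring such as cyclohexyl would do in place of the butyl groups on the amine nitrogen.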